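The source may hold more compounds than are shown below. What is called first, only, known or untested is meant among the compounds shown, and "the series" means these compounds.

In an ADME assay on microsomes from liver (Homo sapiens) for metabolic stability, read by LC-MS, using NADPH, with stated times of 5 min and 30 min, tested at 1 uM (a lower number here means slower removal, a higher number faster removal of the compound), compound 1 `C[C@@H](c1cc2cccnc2cc1F)n1cnc2ncc(-c3cnn(C)c3)nc21` gives 8 uL/min. Compound 2 `CC(c1cc2cc(-c3cnn(C)c3)cnc2cc1F)n1nnc2ncc(-c3ccc(C(N)=O)c(F)c3)nc21` gives 2 uL/min in this assay, and compound 3 `CNC(=O)c1ccc(-c2cnc3nnn(C(C)c4cc5cc(-c6cnn(C)c6)cnc5cc4F)c3n2)cc1F` gives 5 uL/min. Among these three numbers compound 3 stands second highest; its nearest is compound 1, whose number differs from it only within the usual scatter, and its furthest is compound 2, whose number is lower by a gap beyond the scatter. Among the measured compounds shown here, the single step measured between compounds differing in one place is a 2.5-fold higher number from compound 2 to compound 3 (0.40 log units; beyond the scatter), and it concerns methyl in place of hydrogen on an amide-type nitrogen.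

Compound 4 `CNC(=O)c1ccc(-c2cnc3nnn(C(C)c4c(F)cc5ncc(-c6cnn(C)c6)cc5c4F)c3n2)cc1F` differs from compound 3 in a different way: fluoro in place of hydrogen on an aromatic carbon. For the measured compounds named here, no measured step concerns fluoro in place of hydrogen on an aromatic carbon, so the one step from compound 2 to compound 3 does not bear on this change directly. All three measured numbers are low and close together, and nothing here points either way. The expected change is therefore no change at the digits printed from compound 3 to compound 4 (within the scatter), within the scatter. Compound 4 is estimated at 5 uL/min, with a range from 2.5 uL/min to 10 uL/min.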

Compound 4, intrinsic clearance in a liver preparation (reported as CLH), per the amount of preparation that the assay uses: 5 uL/min
Compound 4: middle estimate and measured number agree at the digits printed, and the stated range covers the measured number.
By their numbers in this assay, from the lowest: compound 2; then compounds 3, 4 and 1 (each within the scatter of the next).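

In this assay, the change of fluoro in place of hydrogen on an aromatic carbon gives no change at the digits printed from compound 3 to compound 4 (within the scatter), and this is the first reading of that change among these compounds. It shows that, on compound 3, this position, ortho to a fused ring and ortho to a large group, takes a fluoro group with no visible effect on the speed of removal in the liver preparation. Nothing available explains why the number holds steady at this position.

The compounds shown leave open how a chlorine atom, a methoxy group or an amine at this position would read. They also leave open whether the same fluoro group on compound 2, which carries the amide hydrogen where compound 3 carries a methyl, would leave its number in place.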